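Aryl exchange from compound 3 to compound 4

The source may hold more compounds than are shown below. What is called first, only, known or untested is meant among the compounds shown, and "the series" means these compounds.

In a physicochemical assay for metabolic stability, read by HPLC (a lower number here means that the compound disappears faster, a higher number that the compound lasts longer), compound 1 `Cc1cn([C@H]2C[C@H](N=[N+]=[N-])[C@@H](COP(=O)(O)Oc3ccc(Cl)cc3)O2)c(=O)[nH]c1=O` gives 5.5 h and compound 2 `Cc1cn([C@H]2C[C@H](N=[N+]=[N-])[C@@H](COP(=O)(O)Oc3cncc(Cl)c3)O2)c(=O)[nH]c1=O` gives 7.27 h while compound 3 `Cc1cn([C@H]2C[C@H](N=[N+]=[N-])[C@@H](COP(=O)(O)Oc3cccnc3Cl)O2)c(=O)[nH]c1=O` stands highest of the three (16.3 h). Compound 4 `Cc1cn([C@H]2C[C@H](N=[N+]=[N-])[C@@H](COP(=O)(O)Oc3ccc(Cl)cc3Cl)O2)c(=O)[nH]c1=O` is unmeasured and carries 2,4-dichlorophenyl in place of 2-chloropyridin-3-yl on an oxygen. Two modest steps bear on this (a 3.0-fold higher number from compound 1 to compound 3 (0.47 log units; beyond the scatter)) and (a 2.2-fold higher number from compound 2 to compound 3 (0.35 log units; beyond the scatter)), both beyond the scatter. Another step stays within it (a 1.3-fold higher number from compound 1 to compound 2 (0.12 log units; within the scatter)). Going by the values given here, no measured step isolates this exchange. Compound 4 returns to an aromatic ring of carbon only, as compound 1 has (5.5 h), so a small downward move, not clearly beyond the scatter, is expected (a 1.6-fold lower number from compound 3 to compound 4 (0.21 log units; within the scatter)). The estimate for compound 4 is 10 h (expected range 5 h to 20 h).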

Compound 4, half-life: 3.03 h
For compound 4 the middle estimate is 3.3-fold (0.52 log units) above the measured one, and the stated range ends above it.
By their numbers in this assay, from the lowest: compounds 4, 1 and 2 (each within the scatter of the next, the first and the last beyond it); then compound 3.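

The aryl group on the oxygen matters more than compounds 1 to 3 showed: in this assay, 2,4-dichlorophenyl falls clearly short of both 2-chloropyridin-3-yl (a 5.4-fold lower number from compound 3 to compound 4 (0.73 log units; beyond the scatter)) and 5-chloropyridin-3-yl (a 2.4-fold lower number from compound 2 to compound 4 (0.38 log units; beyond the scatter)). Chloro in place of hydrogen on an aromatic carbon stays within the scatter (a 1.8-fold lower number from compound 1 to compound 4 (0.26 log units; within the scatter)), so this single change does not separate those two compounds. Nothing measured here explains these differences.

Going by these compounds, the step to compound 4 exchanges the ring nitrogen and adds a chloro together, so their separate contributions remain open. Also open, on these data alone, is how 2-chlorophenyl, or an aryl ring carrying an amine or a carboxylic acid, would behave on this oxygen.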